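Dropping the Amino Group: Expected Shift in Lipophilicity

The source may hold more compounds than are shown below. What is called first, only, known or untested is meant among the compounds shown, and "the series" means these compounds.

Compound 1, `CC(C)CN(c1ccc(N(C)C)cc1)S(=O)(=O)c1ccc2c(c1)C(O)CC(C1CCOCC1)O2`: 3.51
Compound 2, `CCc1ccc(N(CC(C)C)S(=O)(=O)c2ccc3c(c2)C(N)CC(C2CCOCC2)O3)cc1`: 3.08
Compound 3, `CCc1ccc(N(CC(C)C)S(=O)(=O)c2ccc3c(c2)C(O)CC(C2CCN(C)CC2)O3)cc1`: 2.67

Of the compounds shown here, three built on a shared core have been measured in a physicochemical assay for lipophilicity, at pH 7.4; on this read-out lower numbers stand for lower lipophilicity and higher numbers for higher lipophilicity. Compound 2 has the second highest of the three numbers: compound 3 lies lower and compound 1 higher, each by more than the usual scatter. Compound 4, `CCc1ccc(N(CC(C)C)S(=O)(=O)c2ccc3c(c2)CCC(C2CCOCC2)O3)cc1`, differs from compound 2 in one place, (hydrogen in place of amino on a saturated ring carbon). Among the measured compounds shown here, no pair of measured compounds shows this change, so its size is not known from data here. Compound 4 is expected to give about 4.3, with a likely range from 3.7 to 4.9. That estimate means an expected upward step a number 1.22 log units higher from compound 2 to compound 4 (beyond the scatter) in this assay, larger than the scatter.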

Compound 4, distribution coefficient: 5.38
Compound 4: middle estimate off by 1.08 log units, on the low side, outside the stated range (above it).
By their numbers in this assay, from the lowest: compound 3; then compound 2; then compound 1; then compound 4.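

Hydrogen in place of amino on this saturated ring carbon gives a number 2.30 log units higher from compound 2 to compound 4 (beyond the scatter) in this assay and puts compound 4 at the top of the four compounds. Among the compounds shown here, this is the first direct reading of the change, and it shows that losing a single heavy atom at this position can produce a large step on this read-out. Nothing at hand explains why the step is this large.

Going by these compounds, how a methoxy group, a fluorine atom or a carboxylic acid on the same carbon would read in this assay remains open. So does whether this step keeps its size when other parts of the shared core change.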